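The source may hold more compounds than are shown below. What is called first, only, known or untested is meant among the compounds shown, and "the series" means these compounds.

Measured so far:

- Compound 1, `Cc1n[nH]cc1-c1cccc2c1CCC2c1ncc[nH]1`, gives 91% in a functional assay on CHO cells for agonist activity at Alpha-1A adrenergic receptor (Homo sapiens), read by FLIPR and calcium flux; on this read-out higher numbers stand for larger maximal responses and lower numbers for smaller maximal responses.
- Compound 2, `c1ccc(-c2cccc3c2CCC3c2ncc[nH]2)nc1`, gives 53% in this assay.
- Compound 3, `COc1cccc2c1CCC2c1ncc[nH]1`, gives 65% in this assay.

All three share one core and differ only in the group carried on one aromatic carbon. Compound 3 stands second highest of the three: it sits a number 12 percentage points higher from compound 2 to compound 3 (beyond the scatter) above its nearest neighbour and a number 26 percentage points lower from compound 1 to compound 3 (beyond the scatter) below compound 1, the largest response seen.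

Compound 4, `CS(=O)(=O)Nc1cccc2c1CCC2c1ncc[nH]1`, is the next step from compound 3. The change is methanesulfonamido in place of methoxy on an aromatic carbon.

For the measured compounds named here, two measured steps bear on this position. Replacing the 3-methyl-1H-pyrazol-4-yl of compound 1 gave a number 26 percentage points lower from compound 1 to compound 3 (beyond the scatter), and the swap from pyridin-2-yl to methoxy gave a number 12 percentage points higher from compound 2 to compound 3 (beyond the scatter). Both are beyond the scatter but neither is dramatic, so this site tolerates change without losing the response outright. The group entering in compound 4 brings a hydrogen-bond donor, as the group of compound 1 does, yet nothing measured matches it closely. The step to compound 4 is therefore expected to be a number 5 percentage points lower from compound 3 to compound 4 (within the scatter), that is, no clear movement beyond the scatter in this assay.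

Compound 4 is estimated at 60%, within a range from 35% to 85%.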

Compound 4, largest response reached (Emax), in percent of the reference or control that the assay uses: 87%
Estimate against measurement, compound 4: 27 percentage points below; measured number above the stated range.
By their numbers in this assay, from the lowest: compound 2; then compound 3; then compounds 4 and 1 (each within the scatter of the next).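

In this assay, the change gives a number 22 percentage points higher from compound 3 to compound 4 (beyond the scatter) and, against the ring-bearing pyridin-2-yl, a number 34 percentage points higher from compound 2 to compound 4 (beyond the scatter), so a group with no ring can carry the response well clear of both compound 2 and compound 3. It also gives a number 4 percentage points lower from compound 1 to compound 4 (within the scatter), which means that the methanesulfonamido group and the 3-methyl-1H-pyrazol-4-yl group cannot be told apart here, although only the second contains a ring, so a ring at this aromatic carbon is not needed for the higher response. Across these four compounds, the two groups with a hydrogen-bond donor give the two higher numbers and none of the four goes against this, but so small a set only shows a pattern, and nothing available explains it.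

The compounds shown leave open whether the amide hydrogen or the sulfonyl part goes with the higher response. A plain amino group, an acetamido group or a methanesulfonamido group with a methyl on its nitrogen at this same carbon would separate those two parts.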